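Swapping the halogen for a methoxy group at the far end

This account rests on a few compounds, and the source may have more. Where it says the series, first, only, none or still open, it means among the compounds named here.

Measured compounds in a functional assay on MCF7 cells (Homo sapiens) for inhibition, read by MTT assay, with a stated time of 72 h; a higher number here means a weaker inhibitor, a lower number a stronger inhibitor:
- compound 1 `Cc1cc(Nc2cc(-c3ccccc3)[nH]n2)n2nc(SCc3ccc(F)cc3)nc2n1` gives 4020 nM
- compound 2 `Cc1cc(Nc2ccn(Cc3ccccc3)n2)n2nc(SCc3ccc(Br)cc3)nc2n1` gives 15800 nM
- compound 3 `Cc1cc(Nc2cc(-c3ccccc3)[nH]n2)n2nc(SCc3ccc(Br)cc3)nc2n1` gives 2720 nM

Compound 3 has the lowest number of the three. Its nearest neighbour is compound 1, which differs from it by a 1.5-fold lower number from compound 1 to compound 3 (0.17 log units; within the scatter), a gap that stays within the scatter, so the two cannot be told apart. Compound 2 sits further off, with a value that lies beyond the scatter from compound 3, but compound 2 differs from compound 3 in more than one place, so no single step can be read from that pair.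

Compound 4 `COc1ccc(CSc2nc3nc(C)cc(Nc4cc(-c5ccccc5)[nH]n4)n3n2)cc1` is the next compound and has not yet been measured. It differs from compound 3 as follows: methoxy in place of bromo on an aromatic carbon. Among the measured compounds shown here, the one step that bears on this change is the exchange of one substituent for another at the same place, a 1.5-fold lower number from compound 1 to compound 3 (0.17 log units; within the scatter), which left the number essentially unchanged. For the measured compounds named here, the change to compound 4 puts a methoxy group where compound 3 carries bromo, and the only comparable step gives no reason to expect a move beyond the scatter in this assay.

Compound 4 is therefore expected to give about 4000 nM, within a range from 1500 nM to 11000 nM. The expected step is a 1.5-fold higher number from compound 3 to compound 4 (0.17 log units; within the scatter).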

Compound 4, half-maximal inhibitory concentration: 4020 nM
The estimate for compound 4 lay 1.0-fold (0.00 log units) below the measured number, and the stated range covers the measured number.
By their numbers in this assay, from the lowest: compounds 3, 1 and 4 (each within the scatter of the next); then compound 2.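

In this assay the move to the 4-methoxybenzyl group gives a 1.5-fold higher number from compound 3 to compound 4 (0.17 log units; within the scatter), so a methoxy group, with its 2 heavy atoms and 1 hydrogen-bond acceptor, takes the place of a single bromine without a shift that can be read. Set against the fluoro compound, the same change gives no change at the digits printed from compound 1 to compound 4 (within the scatter), which means that fluoro, bromo and methoxy on this aromatic carbon cannot be told apart in this assay, whereas the earlier step only exchanged one halogen for another. No measurement on hand accounts for this flat result.

From the compounds shown here alone, this holds for three substituents only, all on the same core, so it remains open whether the number would also stay put with a plain hydrogen on this carbon, or with an amine, a carboxylic acid or a longer chain such as butoxy. Going by these compounds, it is equally open whether the position behaves the same way when the rest of the molecule differs, as it does in compound 2, which has only a bromo group at this place.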